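From Methyl to Trifluoromethyl: Expecting Compound 4

A few compounds are considered here, and "the series" means these few. Any claim that something is new, unique, unknown or untested is made for them only; others in the source may bear on it.

Of the compounds shown here, three sharing a core have been tested in a functional assay on DU-145 cells (Homo sapiens) for cytotoxicity, read by MTT assay, with a stated time of 48 h; a higher number here means a weaker inhibitor, a lower number a stronger inhibitor. Compound 1 `COc1cc(/C=C/c2ccccc2)c(-c2ccccc2)c(OC)c1OC` gives 82000 nM. Compound 2 `C=C(c1ccc(OC)cc1)c1cc(OC)c(OC)c(OC)c1-c1ccccc1` gives 8000 nM, and compound 3 `C=C(c1ccc(C)cc1)c1cc(OC)c(OC)c(OC)c1-c1ccccc1` gives 28000 nM. Among these three numbers compound 3 stands second highest: the number falls a 2.9-fold lower number from compound 1 to compound 3 (0.47 log units; beyond the scatter), yet it rises a 3.5-fold higher number from compound 2 to compound 3 (0.54 log units; beyond the scatter).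

Compound 4 `C=C(c1ccc(C(F)(F)F)cc1)c1cc(OC)c(OC)c(OC)c1-c1ccccc1` differs from compound 3 in one place: trifluoromethyl in place of methyl on an aromatic carbon. Among the compounds with values here, no measured step swaps methyl for trifluoromethyl, so the direction cannot be read from the data. The closest guide is the change from methoxy to methyl on an aromatic carbon, a 3.5-fold higher number from compound 2 to compound 3 (0.54 log units; beyond the scatter), a modest shift; the other step, a 2.9-fold lower number from compound 1 to compound 3 (0.47 log units; beyond the scatter), also modest, alters a larger piece. Both suggest that what sits on this carbon moves the number only modestly, so a modest move in either direction is expected. Compound 4 is therefore estimated at 30000 nM, with a range from 8000 nM to 100000 nM. The step this estimate implies, a 1.1-fold higher number from compound 3 to compound 4 (0.03 log units; within the scatter), is expected to stay small.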

Compound 4, half-maximal inhibitory concentration: 31000 nM
Estimate against measurement, compound 4: 1.0-fold (0.01 log units) below, and the stated range covers the measured number.
By their numbers in this assay, from the lowest: compound 2; then compounds 3 and 4 (each within the scatter of the next); then compound 1.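

In this assay, putting trifluoromethyl in place of methyl on this aromatic carbon, para to a large group, gives a 1.1-fold higher number from compound 3 to compound 4 (0.04 log units; within the scatter), so this exchange of groups leaves the number within the scatter. Methoxy on the same carbon remains apart, with a 3.9-fold higher number from compound 2 to compound 4 (0.59 log units; beyond the scatter), and so among the three groups tried here, only methoxy gives a number separate from the other two. No evidence is available to explain this difference.

The compounds shown leave open whether the lower number is particular to methoxy or would also appear with an amine, a hydroxyl or a longer chain such as ethoxy on this carbon. They also leave open whether the same pattern would hold on a core with its double bond arranged as in compound 1.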